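Tert-butoxy to methoxy on the shared core: solubility notes

This account rests on a few compounds, and the source may have more. Where it says the series, first, only, none or still open, it means among the compounds named here.

Of the compounds shown here, three have been read in a physicochemical assay for solubility, read by LC-MS, in phosphate buffer, measured as kinetic solubility, with a stated time of 24 h, at 25 degrees C, at pH 7.4; on this read-out higher numbers stand for higher solubility and lower numbers for lower solubility. Compound 1 `Nc1nccc(-c2cc3c4c(n[nH]c4c2)Nc2ccncc2O3)n1` gives 10000 nM. Compound 2 `Nc1cc(-c2ccc3c(N)n[nH]c3c2)nc(N)n1` gives 58000 nM. Compound 3 `CC(C)(C)Oc1cc(-c2ccnc(N)n2)cc2[nH]nc(N)c12` gives 68000 nM; its number sits within the scatter of compound 2 and beyond the scatter above compound 1. Among the measured compounds shown here, no two of the three differ in only one place, so no measured step is available.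

Compound 4 `COc1cc(-c2ccnc(N)n2)cc2[nH]nc(N)c12` differs from compound 3 in one place: methyl in place of tert-butyl on an oxygen on an aromatic ring. The change removes three carbon atoms from a chain that carries no donor or acceptor. The step is expected to be small, at most a modest rise in this assay, as a 1.3-fold higher number from compound 3 to compound 4 (0.12 log units; within the scatter). Compound 4 is therefore estimated at 90000 nM, with a range from 40000 nM to 200000 nM.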

Compound 4, solubility: > 100000 nM
Compound 4: no number, only a limit (the forecaster's own chance of this, stated with the estimate: 10%); middle value at least 1.1-fold (0.04 log units) away from the limit.
By their numbers in this assay, from the lowest: compound 1; then compounds 2 and 3 (each within the scatter of the next). At a limit, above all of these: compound 4.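

Among the compounds shown here, the tert-butoxy to methoxy change gives the first measured step that differs in one place: in this assay it is an at least 1.4-fold higher number from compound 3 to compound 4 (0.16 log units; that floor lies within the scatter) and fixes only a floor. Compound 4 reads at a limit and not as a number, so the true size of the step cannot be read. At this oxygen, methyl in place of tert-butyl shows no fall in the reading.

Open, as far as these compounds go, is how ethyl, cyclopropyl or a longer chain on this oxygen would read. Also open, from the compounds shown here alone, is how an amine in place of the whole tert-butoxy group would read.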